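The compounds below may be only part of what the source reports. "The series", "measured", "known", "first", "only" and "open" are said of these compounds alone.

Working notes on the series. Compound 1 `Cc1cc(NC(=O)Nc2ccc(F)cc2)c2ccccc2n1` and compound 2 `Cc1cc(NC(=O)Nc2cccc(N(C)C)c2)c2ccccc2n1` share one core. In an ADME assay on Raji cells (Homo sapiens) for cytotoxicity, with a stated time of 72 h (on this read-out lower numbers stand for an effect already at smaller amounts and higher numbers for an effect only at larger amounts of compound), compound 1 gives > 25000 nM, a limit of the assay. In this assay compound 2 gives > 25000 nM, likewise a limit. Compound 2 thus stands where the whole set stands so far, as both values shown sit at the limit of > 25000 nM in this assay, at which 2 of the 2 values shown sit. Compound 3 `Cc1cc(NC(=O)Nc2cccc(Cl)c2)c2ccccc2n1` is not yet measured; it differs from compound 2 by chloro in place of dimethylamino on an aromatic carbon. Among the measured compounds shown here, no step between measured compounds is known here. The change from compound 2 to compound 3 is expected to give no move beyond the scatter in this assay, a step that the limit leaves unreadable from compound 2 to compound 3. Compound 3 is estimated at 30000 nM, within 10000 nM to 100000 nM.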

Compound 3, half-maximal effective concentration: 18000 nM
Beside the measured number, compound 3's estimate is 1.7-fold (0.22 log units) above it; the measured number falls inside the stated range.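

Compound 3 gives the first number rather than a limit in this assay, so a reading within the range of the assay is now available for this series. Chloro in place of dimethylamino gives an at least 1.3-fold lower number from compound 2 to compound 3 (0.14 log units; that floor lies within the scatter), and 3-chlorophenyl in place of 4-fluorophenyl gives an at least 1.3-fold lower number from compound 1 to compound 3 (0.14 log units; that floor lies within the scatter). The true size of both steps stays unreadable because each starts from a limit: the limit of > 25000 nM in this assay, at which 2 of the 3 values shown sit.

Going by these compounds, whether a carboxylic acid or a methoxy group on this aromatic carbon would give a number or a limit stays open. The compounds shown also leave open how the shared core behaves without its methyl group.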